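A few compounds are considered here, and "the series" means these few. Any claim that something is new, unique, unknown or untested is made for them only; others in the source may bear on it.

Measured compounds:
Compound 1, `CC(OC1=NCCN1)c1ccccc1`: 166 nM
Compound 2, `Cc1ccccc1C(C)OC1=NCCN1`: 269 nM

Both were run in an assay on CHO cells for displacement of a labelled ligand from Alpha-2B adrenergic receptor (Homo sapiens), read by scintillation counting, with a stated time of 30 min; on this read-out higher numbers stand for weaker inhibition and lower numbers for stronger inhibition. Compound 2 stands beside compound 1 within the scatter, the step of a 1.6-fold higher number from compound 1 to compound 2 (0.21 log units; within the scatter) being too small to read as a change. Compound 3, `CCCc1ccccc1C(C)OC1=NCCN1`, is not yet measured; it differs from compound 2 by ethyl in place of hydrogen on a saturated chain carbon bound to an aromatic carbon, which, cut one bond further out, reads as methyl to propyl. Within the data shown here, the only measured step that bears on this is the one from compound 1 to compound 2, where a methyl entered on an aromatic carbon and the number moved within the scatter. Growing that group further has no measured precedent here, so a step of a 1.5-fold higher number from compound 2 to compound 3 (0.17 log units; within the scatter) is expected, with the direction uncertain and most likely within or only just beyond the scatter. Compound 3 is therefore estimated at 400 nM, in a range from 150 nM to 1200 nM.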

Compound 3, inhibition constant: 537 nM
Compound 3: middle estimate off by 1.3-fold (0.13 log units), on the low side; the measured number falls inside the stated range.
By their numbers in this assay, from the lowest: compounds 1, 2 and 3 (each within the scatter of the next, the first and the last beyond it).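

Extending the methyl to propyl gives a 2.0-fold higher number from compound 2 to compound 3 (0.30 log units; within the scatter), and that step alone cannot be read as a change. Among these compounds, measured against hydrogen on the aromatic carbon, however, propyl gives a 3.2-fold higher number from compound 1 to compound 3 (0.51 log units; beyond the scatter), the first step that can be read, and it is a modest weakening of inhibition that the methyl step did not show. Nothing available here accounts for this weakening.

The compounds shown leave open whether a longer chain such as butyl would weaken inhibition further on this aromatic carbon, or whether the effect belongs to alkyl groups alone. A methoxy group or a chlorine atom in the same place could answer the second question, which three compounds cannot settle.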